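This account rests on a few compounds, and the source may have more. Where it says the series, first, only, none or still open, it means among the compounds named here.

Working notes on the series. The shared core is that of compound 1 `COc1cc(-c2nn(-c3cccc(NC(=O)Nc4cc(C(F)(F)F)cc(C(F)(F)F)c4)c3)cc2-c2ccncc2)ccc1Cl`, which in a functional assay on SNB-19 cells (Homo sapiens) for inhibition, read by sulforhodamine B assay, with a stated time of 48 h (a higher number here means a weaker inhibitor of growth, a lower number a stronger inhibitor of growth), gives 3670 nM. Compound 2 `COc1cc(-c2nn(-c3cccc(NC(=O)Nc4ccc(Cl)c(Cl)c4)c3)cc2-c2ccncc2)ccc1Cl` returns only a limit of this assay, > 50000 nM. This is the limit of > 50000 nM in this assay, at which 1 of the 2 values shown sits. Compound 3 `COc1cc(-c2nn(-c3cccc(NC(=O)Nc4cccc(C(F)(F)F)c4)c3)cc2-c2ccncc2)ccc1Cl` carries 3-(trifluoromethyl)phenyl in place of 3,4-dichlorophenyl on an amide-type nitrogen. For the measured compounds named here, no measured pair shows this change, so the size of the step is open. Compound 1 gives 3670 nM in this assay, so a number rather than a limit is reached within the series. The step is expected as a gain beyond the scatter, an at least 3.3-fold lower number from compound 2 to compound 3 (0.52 log units; beyond the scatter), with a limit still possible. Compound 3 is estimated at 15000 nM, between 4000 nM and 50000 nM.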

Compound 3, concentration for total growth inhibition: 4000 nM
The estimate for compound 3 lay 3.8-fold (0.57 log units) above the measured number; the range from low to high includes it.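

In this assay, 3-(trifluoromethyl)phenyl in place of 3,4-dichlorophenyl on the amide-type nitrogen gives an at least 12-fold lower number from compound 2 to compound 3 (1.09 log units; beyond the scatter), so the aryl group at this position decides whether a number is reached at all. A second trifluoromethyl is not needed for that number: hydrogen in its place on an aromatic carbon gives a 1.1-fold higher number from compound 1 to compound 3 (0.04 log units; within the scatter). The first step stays open-ended, as compound 2 is only a limit: the limit of > 50000 nM in this assay, at which 1 of the 3 values shown sits.

Which chlorine of the 3,4-dichlorophenyl matters remains open. So does how a phenyl carrying an amine or a carboxylic acid at this position would read in this assay.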